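The compounds below may be only part of what the source reports. "The series", "measured", "known", "first", "only" and "open" are said of these compounds alone.

Measured so far in a functional assay on the whole organism with Scenedesmus acutus as the target (on this read-out lower numbers stand for stronger inhibition and higher numbers for weaker inhibition), are two compounds:

- Compound 1 `CC(C)OC(=O)c1cc(N2C(=O)C3=C(CCCC3)C2=O)ccc1Cl` gives 1000 nM
- Compound 2 `CCCCCOC(=O)c1cc(N2C(=O)C3=C(CCCC3)C2=O)ccc1Cl` gives 9330 nM

Compound 2 has the higher of these two numbers, so it is the weaker inhibitor of the pair. Compound 3 `CCCCCCCCOC(=O)c1cc(N2C(=O)C3=C(CCCC3)C2=O)ccc1Cl` extends the chain of compound 2 through the change propyl in place of hydrogen on a saturated chain carbon, five bonds along the chain from an oxygen next to a carbonyl group in the form of propyl in place of hydrogen on a saturated chain carbon, five bonds along the chain from an oxygen next to a carbonyl group. Among the measured compounds shown here, only one measured step bears on this, namely a 9.3-fold higher number from compound 1 to compound 2 (0.97 log units; beyond the scatter) when pentyl took the place of isopropyl on an oxygen next to a carbonyl group. A further rise in this assay is therefore expected, although a single step cannot fix its size. The expected move is a 2.7-fold higher number from compound 2 to compound 3 (0.43 log units; beyond the scatter) according to this estimate. For compound 3 the estimated value is 25000 nM with an expected range from 6000 nM to 100000 nM around it.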

Compound 3, half-maximal inhibitory concentration: > 100000 nM
Compound 3 was reported as a limit; the forecaster's own chance of this, stated with the estimate: 20%; middle value at least 4.0-fold (0.60 log units) away from the limit.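

In this assay compound 3 gives > 100000 nM, which is a limit of the assay and not a number. Adding propyl to the end of the pentyl chain produces an at least 10-fold higher number from compound 2 to compound 3 (1.03 log units; beyond the scatter), and the whole change from isopropyl to octyl on this oxygen produces an at least 100-fold higher number from compound 1 to compound 3 (2.00 log units; beyond the scatter), so across these three compounds the number keeps rising as the chain grows, with none going against this trend. The true size of both steps stays unknown, as the result for compound 3 reaches the top of what can be read: the limit of > 100000 nM in this assay, at which 1 of the 3 values shown sits.

Still open, as far as these compounds go, is whether a shorter group such as methyl or ethyl on this oxygen would give a lower number than compound 1. Also open, from the compounds shown here alone, is how a carboxylic acid, or a chain carrying an amine, would behave at this position.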